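This account rests on a few compounds, and the source may have more. Where it says the series, first, only, none or still open, it means among the compounds named here.

Compound 3, with the structure `Cc1cccc(F)c1Oc1cccc(F)c1OC1CNC1`, was tested in an assay on isolated protein for displacement of a labelled ligand from sodium-dependent dopamine transporter (Homo sapiens), read by scintillation proximity assay; on this read-out higher numbers stand for weaker inhibition and lower numbers for stronger inhibition. For compound 3 this assay reports only a limit, > 6460 nM, not a number. Compound 1, `Fc1cccc(Cl)c1Oc1cccc(F)c1OC1CCNCC1`, likewise gives only a limit, > 6370 nM. Compound 2, `Fc1cccc(Oc2ccccc2Cl)c1OC1CNC1`, gives 4700 nM in this assay. Compound 3 therefore sits at the edge of what this assay can measure, without a number of its own. Compound 4, `Fc1ccccc1Oc1cccc(F)c1OC1CNC1`, differs from compound 3 by one change: hydrogen in place of methyl on an aromatic carbon. For the measured compounds named here, no measured pair shows this change, so its size is unknown; the step in this assay, a step that the limit leaves unreadable from compound 3 to compound 4, is expected to be small, in either direction and within the usual scatter. Compound 4 is expected to give 7000 nM, with a likely range from 2500 nM to 20000 nM.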

Compound 4, inhibition constant: > 4860 nM
Compound 4 was reported as a limit (the forecaster's own chance of this, stated with the estimate: 60%); the middle value lies beyond the limit too.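

Taking away the methyl does not bring a measured number into view in this assay: like compound 3, compound 4 gives only a limit, > 4860 nM. With limits on both sides, the step for hydrogen in place of methyl cannot be read. Fluoro in place of chloro on an aromatic carbon gives an at least 1.0-fold higher number from compound 2 to compound 4 (0.01 log units; that floor lies within the scatter), so this change may be small or larger, and no real difference can be claimed.

Open, going by these compounds, is whether any other group at this position, such as a methoxy group or an amine, would give a number rather than a limit in this assay.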